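A tert-butyl in place of hydroxy on a thiadiazole

The source may report more compounds than this note shows. Statements on the series, on what has been measured and on what is new or still open speak of the compounds shown alone.

Of the compounds shown here, three have been measured in an assay on microsomes from liver for inhibition of acyl-CoA desaturase 1 (Rattus norvegicus); a lower number here means a stronger inhibitor, a higher number a weaker inhibitor. Compound 1, with the structure `Oc1nnc(-c2ccc(N3CCC(Oc4ccccc4C(F)(F)F)CC3)nn2)s1`, gives 6.1 nM. Compound 2, with the structure `N#Cc1ccccc1OC1CCN(c2ccc(-n3ccnc3)nn2)CC1`, gives 236 nM, and compound 3, with the structure `FC(F)(F)c1cccc(OC2CCN(c3ccc(-n4ccnc4)nn3)CC2)c1`, gives 19 nM. Compound 1 therefore carries the lowest number of the three and is the strongest inhibitor in this set: compound 3 is the nearest to it, compound 2 the furthest, and both gaps lie beyond the usual scatter.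

Compound 4, with the structure `CC(C)(C)c1nnc(-c2ccc(N3CCC(Oc4ccccc4C(F)(F)F)CC3)nn2)s1`, has not yet been measured. It differs from compound 1 in a single place: tert-butyl in place of hydroxy on an aromatic carbon. For the measured compounds named here, no measured pair in this set shows such a change, so there is no direct precedent to rest on. The hydroxy-bearing compound 1 is the most potent member, and its replacement by a tert-butyl is expected to cost some potency, with an estimated step of a 2.5-fold higher number from compound 1 to compound 4 (0.39 log units; beyond the scatter) that is modest and may not clear the scatter. Compound 4 is thus expected to give about 15 nM, most likely between 3 nM and 80 nM.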

Compound 4, half-maximal inhibitory concentration: 710 nM
Estimate against measurement, compound 4: 47-fold (1.68 log units) below; the measured number lies above the stated range.
By their numbers in this assay, from the lowest: compound 1; then compound 3; then compound 2; then compound 4.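

In this assay the change from hydroxy to tert-butyl on the five-membered aromatic ring gives a 120-fold higher number from compound 1 to compound 4 (2.07 log units; beyond the scatter) and so shows that potency is highly sensitive to the group on this ring carbon. The change replaces a group that has a hydrogen-bond donor and acceptor with a larger, all-carbon group that has neither, and this single pair cannot separate those differences. Nothing available here accounts for the loss of potency.

From the compounds shown here alone, an amine or a methyl on this same carbon could help to separate those differences, but whether either would stay close to compound 1 or fall toward compound 4 remains open. Also open, going by these compounds, is whether a methoxy group, which keeps the oxygen but lacks the hydroxy hydrogen, would retain the potency of compound 1.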